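The compounds below may be only part of what the source reports. "The series", "measured", "known", "first", "only" and "open" are said of these compounds alone.

Working notes on a small set sharing a piperazine-linked chloroquinoline side chain. Compound 1 `O=C1C(=O)N(CN2CCN(c3ccnc4cc(Cl)ccc34)CC2)c2cccc(Br)c21` and compound 2 `O=C1C(=O)N(CN2CCN(c3ccnc4cc(Cl)ccc34)CC2)c2ccccc21` have the same core and differ only by hydrogen in place of bromo on an aromatic carbon. In an ADME assay on 184B5 cells (Homo sapiens) for cytotoxicity, read by sulforhodamine B assay, with a stated time of 48 h (on this read-out lower numbers stand for stronger inhibition of growth and higher numbers for weaker inhibition of growth), compound 1 gives 49000 nM, and compound 2 gives 71700 nM, so that the measured step is a 1.5-fold higher number from compound 1 to compound 2 (0.17 log units; within the scatter) and the two numbers cannot be told apart.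

Compound 3 `NC(=S)N/N=C1/C(=O)N(CN2CCN(c3ccnc4cc(Cl)ccc34)CC2)c2cc(Br)ccc21` carries a different core, and the difference between the two cores is not broken down here. In this assay compound 3 gives 13100 nM, the lowest of the three numbers, with compound 1 the nearest and compound 2 the furthest, both gaps beyond the scatter.

Compound 4 `NC(=S)N/N=C1/C(=O)N(CN2CCN(c3ccnc4cc(Cl)ccc34)CC2)c2ccccc21` is not yet measured. Against compound 3 it shows (hydrogen in place of bromo on an aromatic carbon). This is the same kind of change as that from compound 1 to compound 2, occurring twice among the compounds shown, but not the same: in compound 1 the bromo sits ortho to a fused ring and meta to a fused ring, whereas in compound 3 it sits meta to a fused ring and para to a fused ring.

For compound 4 the expected step is a 1.4-fold higher number from compound 3 to compound 4 (0.14 log units; within the scatter), set beside the measured 1.5-fold higher number from compound 1 to compound 2 (0.17 log units; within the scatter), and it rests on that earlier step lying within the scatter. Compound 4 is accordingly estimated at 18000 nM, with a range from 9000 nM to 40000 nM.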

Compound 4, concentration for 50% growth inhibition: 28800 nM
Compound 4: middle estimate off by 1.6-fold (0.20 log units), on the low side, and the stated range covers the measured number.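

In this assay, hydrogen in place of bromo on an aromatic carbon gives a 2.2-fold higher number from compound 3 to compound 4 (0.34 log units; beyond the scatter), a modest step on the core of compound 3. Set beside the same change on the core of compound 1, the size of this step cannot be told apart from the earlier one: the same change on two cores in this assay, a 1.5-fold higher number (0.17 log units; within the scatter) from compound 1 to compound 2 and a 2.2-fold higher number (0.34 log units; beyond the scatter) from compound 3 to compound 4, 1.5-fold (0.18 log units) apart, within the scatter of two such steps. Among the compounds shown here, this supports carrying the change between these two cores as a first approximation, but it rests on only two pairs, one of them a step within the scatter, and the bromo stands at a different place in each pair, meta to a fused ring and para to a fused ring in compound 3 only, so the effects of core and place are not separated and no general rule follows.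

On these data alone, it remains open whether bromo at one and the same place on both cores would give steps of matching size. As far as these compounds go, it also remains open whether a different group at that place, such as chloro, methoxy or an amine, would carry between the cores in the same way.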